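Trifluoromethyl to Cyano on a Fused Aromatic Ring

A few compounds are considered here, and "the series" means these few. Any claim that something is new, unique, unknown or untested is made for them only; others in the source may bear on it.

Compound 1 `Cc1ncccc1-c1cnc(NCc2c(F)cc(N)c3c2CCO3)n2cnnc12`: in an assay on isolated protein for binding affinity to Polycomb protein EED (Homo sapiens), read by surface plasmon resonance (a higher number here means weaker binding, a lower number tighter binding), compound 1 gives 500 nM.
Compound 2 `Cc1ncccc1-c1cnc(NCc2c(F)cc(C(F)(F)F)c3c2CCO3)n2cnnc12`: in this assay compound 2 gives "not determined" (no result reported).

The two compounds share one core and differ only in the group on the six-membered aromatic ring of the fused system. Compound 2 stands nowhere on the numbers: no dissociation constant was recorded for it, so it offers no anchor of its own. Compound 3 `Cc1ncccc1-c1cnc(NCc2c(F)cc(C#N)c3c2CCO3)n2cnnc12` arises from compound 2 through (cyano in place of trifluoromethyl on an aromatic carbon). Among the compounds with values here, with no number for compound 2 and no measured step in this assay, neither the size nor the direction of this change can be read from the data; no step beyond the usual scatter is assumed either way. Within the data shown here, the only measured relative is compound 1, which carries an amino group at that same place. Because compound 1 gives 500 nM, compound 3 is expected to land in a similar region, with wide uncertainty. Compound 3 is estimated at 400 nM, expected between 60 nM and 3000 nM.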

Compound 3, dissociation constant: 15000 nM
For compound 3 the middle estimate is 38-fold (1.57 log units) below the measured one; measured number outside the range, above it.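

The group at this place on the aromatic ring matters in this assay: cyano in place of amino gives a 30-fold higher number from compound 1 to compound 3 (1.48 log units; beyond the scatter), a large step that shows binding is much weaker with cyano on the otherwise unchanged core. Within the data shown here, the change from trifluoromethyl to cyano itself cannot be read, as compound 2 has no number, which leaves amino against cyano as the only measured comparison at this place. No supporting measurement bears on the reason for this step.

Two measured compounds cannot show whether amino helps binding or cyano harms it. Going by these compounds, it also remains open whether a methylamino group, a hydroxyl group or a carboxamide at this place would stay close to compound 1 at 500 nM or fall nearer to compound 3 at 15000 nM.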